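The source may hold more compounds than are shown below. What is called first, only, known or untested is meant among the compounds shown, and "the series" means these compounds.

In a functional assay on MT4 cells (Homo sapiens) for cytotoxicity (on this read-out higher numbers stand for lower toxicity in this test and lower numbers for higher toxicity in this test), compound 1 (`CC(C)Sc1nc(Cc2c(F)cccc2F)cc(=O)[nH]1`) gives > 200000 nM, which is a limit and not a number. Compound 2 (`CCC(C)Sc1nc(O)cc(Cc2c(F)cccc2F)n1`) gives > 200000 nM, which is also a limit. Compound 2 therefore stands at the limit of > 200000 nM in this assay, at which 2 of the 2 values shown sit, with no exact value to anchor it. Compound 3 (`CCC(C)Sc1nc(O)c(C)c(Cc2c(F)cccc2F)n1`) differs from compound 2 as follows: methyl in place of hydrogen on an aromatic carbon, with the methyl on an aromatic carbon, ortho to a hydroxy group. Among the compounds with values here, no measured step shows the effect of this change, so no shift beyond the usual scatter is expected in this assay. The expected size is an at least 1.1-fold lower number from compound 2 to compound 3 (0.04 log units; that floor lies within the scatter). For compound 3 the estimated value is 180000 nM, with an expected range of 80000 nM to 300000 nM.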

Compound 3, half-maximal cytotoxic concentration: 200000 nM
Compound 3: middle estimate off by 1.1-fold (0.05 log units), on the low side; the range from low to high includes it.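

In this assay compound 3 gives 200000 nM, the first exact value among the compounds shown, so with methyl on this aromatic carbon, ortho to a hydroxy group, the read-out can be stated as a number. Compound 2 gives > 200000 nM, which is a limit. Methyl in place of hydrogen on this aromatic carbon gives a number no higher from compound 2 to compound 3 (the limit leaves the size open). The size of this step cannot be read, because compound 2 stands only at a limit: the limit of > 200000 nM in this assay, at which 2 of the 3 values shown sit.

What the compounds shown leave open is how a longer chain, an amine or a carboxylic acid on this carbon would read in this assay.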